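Swapping a Hydroxy for a Methyl

The compounds below may be only part of what the source reports. "The series", "measured", "known", "first", "only" and "open" are said of these compounds alone.

In a functional assay on A549 cells (Homo sapiens) for antiproliferative activity, read by MTT assay, with a stated time of 48 h (a higher number here means a weaker inhibitor, a lower number a stronger inhibitor), compound 1 `COc1ccc(-c2cncc3[nH]c(=O)n(Cc4cc(OC)c(OC)c(OC)c4)c23)cc1O` reports only a limit, > 20000 nM. Among the measured compounds shown here, compound 2 `COc1ccc(-c2cc3c(cn2)[nH]c(=O)n3-c2cc(OC)c(OC)c(OC)c2)cc1O` gives 630 nM, so it holds the only true number so far. Compound 3 `COc1ccc(-c2cc3c(cn2)[nH]c(=O)n3-c2cc(OC)c(OC)c(OC)c2)cc1C` keeps the core of compound 2 but carries methyl in place of hydroxy on an aromatic carbon, ortho to a methoxy group (methyl in place of hydroxy on an aromatic carbon). For the measured compounds named here, no measured pair yet shows what this swap does in this assay, so only a small loss of strength is expected, with the estimated 1.3-fold higher number from compound 2 to compound 3 (0.10 log units; within the scatter) staying within the usual scatter. The estimate for compound 3 is 800 nM, with an expected range of 180 nM to 4000 nM.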

Compound 3, half-maximal inhibitory concentration: 1910 nM
Estimate against measurement, compound 3: 2.4-fold (0.38 log units) below; the range from low to high includes it.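

Among the compounds shown here, this is the first measured look at this position: changing 3-hydroxy-4-methoxyphenyl to 4-methoxy-3-methylphenyl in this assay gives a 3.0-fold higher number from compound 2 to compound 3 (0.48 log units; beyond the scatter) as a modest loss of strength, beyond the usual scatter. The hydroxy therefore cannot be swapped for a methyl here without some cost, although compound 3 still gives a true number rather than a limit. Whether an amine, a fluorine or a longer chain at this position would keep the strength of compound 2 remains open, and nothing measured here explains the loss.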